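Hydrazone series: replacing the substituted aryl of compound 2

A few compounds are considered here, and "the series" means these few. Any claim that something is new, unique, unknown or untested is made for them only; others in the source may bear on it.

Measured in a functional assay on MCF7 cells (Homo sapiens) for cytotoxicity, read by MTT assay, with a stated time of 72 h; on this read-out higher numbers stand for weaker inhibition and lower numbers for stronger inhibition:
- compound 1 `COc1cc2ncnc(Nc3ccc(F)c(Cl)c3)c2cc1NC(=O)N/N=C/c1ccc(O)c(Br)c1`: "not active" (no number reported)
- compound 2 `CCN(CC)c1ccc(/C=N/NC(=O)Nc2cc3c(Nc4ccc(F)c(Cl)c4)ncnc3cc2OC)c(O)c1`: 27300 nM

Going by the values given here, compound 2 gives 27300 nM, the only number available in this assay. Compound 1 reads "not active" (no number reported), with no number, so the two cannot be ranked by size.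

Next in line is compound 3 `COc1cc2ncnc(Nc3ccc(F)c(Cl)c3)c2cc1NC(=O)N/N=C/c1ccc(O)cc1`. The change from compound 2 is 4-hydroxyphenyl in place of 4-(diethylamino)-2-hydroxyphenyl on a carbon with a double bond to nitrogen.

Among the compounds with values here, no measured pair differing in one place exists, so nothing calibrates this step. With compound 2 at 27300 nM and compound 1 at "not active" (no number reported), the evidence leans towards weak inhibition, and a shift towards weaker inhibition is expected. The expected change is a 1.4-fold higher number from compound 2 to compound 3 (0.14 log units; within the scatter), which may stay within the scatter. Compound 3 is estimated at 38000 nM, within a range of 14000 nM to 100000 nM.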

Compound 3, half-maximal inhibitory concentration: 28600 nM
For compound 3 the middle estimate is 1.3-fold (0.12 log units) above the measured one; the measured number falls inside the stated range.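

In this assay, going by these compounds alone, 4-hydroxyphenyl in place of 4-(diethylamino)-2-hydroxyphenyl on a carbon with a double bond to nitrogen gives a 1.0-fold higher number from compound 2 to compound 3 (0.02 log units; within the scatter), the only step in this set that can be read. At this position, the group can therefore go from 12 heavy atoms to 7 without a difference that stands out from the scatter, and the result does not depend on keeping the diethylamino group. No measured property bears on this outcome, so it stays an observation without an explanation.

Steps to compound 1 cannot be read: compound 1 reads "not active" (no number reported). Also open, from the compounds shown here alone, is how a carboxylic acid, a morpholine or a longer alkyl chain on the 4-hydroxyphenyl ring would read in this assay.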